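The compounds below may be only part of what the source reports. "The series", "measured", "known", "first", "only" and "open" are said of these compounds alone.

Measured so far in this series:

compound 1, `COc1cccc(Cn2cnc3sc(-c4ccncc4)cc3c2=O)c1`: 6 nM
compound 2, `COc1cccc(Cn2cnc3sc(-c4ccnc(OC)c4)cc3c2=O)c1`: 6920 nM
compound 3, `COc1ccc(Cn2cnc3sc(-c4ccnc(N)c4)cc3c2=O)cc1`: 46 nM

All three were run in an assay on isolated protein for inhibition of Rho-associated protein kinase 2 (Homo sapiens), read by radiometric assay and 33P incorporation, with a stated time of 40 min, in the presence of a further agent that is not named here; on this read-out higher numbers stand for weaker inhibition and lower numbers for stronger inhibition. Compound 1 gives 6 nM in this assay. Compound 2 gives 6920 nM. Compound 3 gives 46 nM.

Compound 1 and compound 2 differ by a single change, (methoxy in place of hydrogen on an aromatic carbon), and the measured step is a 1200-fold higher number from compound 1 to compound 2 (3.06 log units; beyond the scatter). Compound 1 and compound 3 share a core whose difference is not broken down here; the two values only show compound 3 at a higher number than compound 1 in this assay.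

Compound 4, `COc1ccc(Cn2cnc3sc(-c4ccnc(N)c4)cc3c2=O)cc1OC`, is not yet measured. It differs from compound 3 by methoxy in place of hydrogen on an aromatic carbon. Within the data shown here, this is the same kind of change as the one from compound 1 to compound 2, but not the same: there the methoxy entered on a six-membered aromatic ring with one nitrogen, next to the ring nitrogen, meta to a large group; here it enters on a six-membered aromatic ring of carbon only, ortho to a methoxy group, meta to a large group.

Among the measured compounds shown here, the only measured step for this change, a 1200-fold higher number from compound 1 to compound 2 (3.06 log units; beyond the scatter), belongs to the other place, so it is not taken over as a template for compound 4. For the measured compounds named here, a small step is expected, a 1.3-fold higher number from compound 3 to compound 4 (0.12 log units; within the scatter), resting on compound 3 at 46 nM as the anchor and on no measured step at this place. Compound 4 is expected to give 60 nM in this assay, with a range from 15 nM to 250 nM.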

Compound 4, half-maximal inhibitory concentration: 219 nM
For compound 4 the middle estimate is 3.7-fold (0.56 log units) below the measured one, and the stated range covers the measured number.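

Methoxy in place of hydrogen on an aromatic carbon gives a higher number at both places shown in this assay, here with a 4.8-fold higher number from compound 3 to compound 4 (0.68 log units; beyond the scatter), but the size of the step does not carry over from one core to the other: the same change on two cores in this assay, a 1200-fold higher number (3.06 log units; beyond the scatter) from compound 1 to compound 2 and a 4.8-fold higher number (0.68 log units; beyond the scatter) from compound 3 to compound 4, 240-fold (2.38 log units) apart, beyond the scatter of two such steps

Only the direction is shared, and two steps are too few to make that direction a rule for the series. These steps also differ in more than one respect: one methoxy enters on a six-membered aromatic ring with one nitrogen, the other on a six-membered aromatic ring of carbon only, and the compounds around them differ as well, so the data do not show how much of the gap belongs to the place of the change and how much to the rest of the structure.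

Open, on these data alone, is whether fluorine, chlorine or a hydroxyl group on the same aromatic carbon of compound 3 would give a step like that of methoxy. Also open, as far as these compounds go, is the step for this change on the ring of carbon only when the rest of the structure is that of compound 1, a comparison that would separate place from surroundings.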